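The compounds below may be only part of what the source reports. "The series", "measured", "known", "first", "only" and "open" are said of these compounds alone.

Compounds measured in a functional assay on 1A9/ptx-10 cells (Homo sapiens) for inhibition; on this read-out higher numbers stand for weaker inhibition and lower numbers for stronger inhibition:
- Compound 1 `COc1ccc2cc1Oc1ccc(cc1)C1OC1COC(=O)CC2`: > 2500 nM, a limit
- Compound 2 `COc1ccc2cc1Oc1ccc(cc1)CC(I)COC(=O)CC2`: > 2500 nM, a limit
- Compound 3 `COc1ccc2cc1Oc1ccc(cc1)CC(O)COC(=O)CC2`: > 2500 nM, a limit

Compound 3 has no number in this assay, and its > 2500 nM is a limit. The series as a whole stands at the limit of > 2500 nM in this assay, at which 3 of the 3 values shown sit.

The next compound is compound 4 `COc1c(Br)cc2cc1Oc1ccc(cc1)CC(O)COC(=O)CC2`, which carries bromo in place of hydrogen on an aromatic carbon, ortho to a methoxy group: bromo in place of hydrogen on an aromatic carbon.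

For the measured compounds named here, the only measured step is a step that the two limits leave unreadable from compound 2 to compound 3. It concerns a saturated ring carbon, not the aromatic carbon changed here, and it gives no size to carry over. Going by the values given here, no measured compound carries a bromo group. With no readable step, no sizeable gain is expected, and the most likely result for compound 4 is the same limit.

The expected change is a step that the limit leaves unreadable from compound 3 to compound 4, a loose figure given the limit on compound 3.

For compound 4 the estimated value is 4000 nM, with an expected range from 1500 nM to 15000 nM.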

Compound 4, half-maximal inhibitory concentration: > 2500 nM
Compound 4 gave a limit, no number; the forecaster's own chance of this, stated with the estimate: 75%; the middle value lies beyond the limit too.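

Compound 3 and compound 4 both give only a limit in this assay, so the step between them cannot be read. The compounds shown leave open whether any change to the shared core yields an actual number, with the series standing here: the limit of > 2500 nM in this assay, at which 4 of the 4 values shown sit.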